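The compounds below may be only part of what the source reports. "The series", "measured", "known", "first", "only" and "open" are said of these compounds alone.

Compound 1 `Cc1nc(N)c2c(-c3ccccc3)cn([C@@H]3O[C@H](CO)[C@@H](O)[C@H]3O)c2n1` was tested for its effect on tumour cell growth in a functional assay on HeLa S3 cells (Homo sapiens) for antiproliferative activity, read by XTT assay, with a stated time of 72 h; a higher number here means a weaker inhibitor, a lower number a stronger inhibitor. In this assay compound 1 gives > 20000 nM, which is a limit of the assay and not a number. Compound 2 `Nc1nc(N)c2c(-c3ccccc3)cn([C@@H]3O[C@H](CO)[C@@H](O)[C@H]3O)c2n1`, with amino in place of methyl on an aromatic carbon, gives > 20000 nM, again a limit. The step that the two limits leave unreadable from compound 1 to compound 2 cannot be read because both values sit at the limit of > 20000 nM in this assay, at which 2 of the 3 values shown sit. Compound 3 `CSc1ncnc2c1c(-c1ccoc1)cn2[C@@H]1O[C@H](CO)[C@@H](O)[C@H]1O` gives 5390 nM. Compound 4 `Cc1nc(N)c2c(-c3ccoc3)cn([C@@H]3O[C@H](CO)[C@@H](O)[C@H]3O)c2n1` differs from compound 1 by furan-3-yl in place of phenyl on an aromatic carbon. Within the data shown here, no measured step carries this change; compound 3 holds the furan-3-yl, yet on a differently substituted core, so it is only a loose guide. The expected step of an at least 1.3-fold lower number from compound 1 to compound 4 (0.12 log units; that floor lies within the scatter) would place compound 4 near 15000 nM, estimated between 5000 nM and 50000 nM, with a real chance of a limit again.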

Compound 4, half-maximal inhibitory concentration: > 20000 nM
Compound 4: no number, only a limit; the forecaster's own chance of this, stated with the estimate: 55%; middle value at least 1.3-fold (0.12 log units) from the limit.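

Compound 1 and compound 4 both give only a limit in this assay, so the step between them cannot be read: the limit of > 20000 nM in this assay, at which 3 of the 4 values shown sit. The compounds shown leave open whether furan-3-yl and phenyl differ at all on the core of compound 1.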